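Hydroxyl for Fluorine on a Benzylamide Side Chain

The source may hold more compounds than are shown below. What is called first, only, known or untested is meant among the compounds shown, and "the series" means these compounds.

Compound 1 `CC(C)Cc1nn(-c2nccs2)cc1C(=O)NCc1cccc(F)c1` was examined in a toxicity assay on HepG2 2.2.15 cells (Homo sapiens) for cytotoxicity, read by CCK-8 assay, with a stated time of 8 days; a higher number here means that more compound is tolerated, a lower number that less compound is tolerated. For compound 1 this assay gives only the limit of > 100000 nM, so a limit rather than a number is known for it (the limit of > 100000 nM in this assay, at which 1 of the 3 values shown sits). Two further compounds give numbers. Compound 2 `CC(C)Cc1nn(-c2cccc(F)c2)cc1C(=O)NCc1ccccc1` gives 85900 nM in this assay, and compound 3 `CCOC(=O)c1cn(-c2ccccc2[N+](=O)[O-])nc1CC(C)C` gives 4850 nM, the lower of the two. Among the measured compounds shown here, no step between two measured compounds that differ in only one place is available, so compound 1 is placed only by sitting at the limit while the other two sit below it, compound 3 clearly so.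

Compound 4 `CC(C)Cc1nn(-c2nccs2)cc1C(=O)NCc1ccc(O)cc1` is not yet measured. It differs from compound 1 by 4-hydroxyphenyl in place of 3-fluorophenyl on a saturated chain carbon bound to an amide-type nitrogen. For the measured compounds named here, no measured step of this kind exists among the three compounds, and the change is expected to move the value by none beyond the scatter; the estimated step is a number no higher from compound 1 to compound 4 (the limit leaves the size open). Compound 4 is therefore expected to give 100000 nM in this assay, with a range from 40000 nM to 250000 nM. For compound 4 a limit rather than a number is expected to be the more likely report, as it was for compound 1.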

Compound 4, half-maximal cytotoxic concentration: > 100000 nM
Compound 4: only a limit was reported; the forecaster's own chance of this, stated with the estimate: 60%; the middle value sits exactly at the limit.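

In this assay compound 4 gives > 100000 nM, a limit and not a number. Among the compounds shown here, compound 1 gives > 100000 nM, also a limit, so no step between compound 1 and compound 4 can be read. The compounds shown leave open whether 4-hydroxyphenyl in place of 3-fluorophenyl changes the tolerated concentration at all, and in which direction.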